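A few compounds are considered here, and "the series" means these few. Any claim that something is new, unique, unknown or untested is made for them only; others in the source may bear on it.

Compound 1, `COc1ccc(-c2cc3cc(C)ccc3c(-c3cccc(O)c3)n2)cc1OC`: 4340 nM
Compound 2, `COc1cccc(-c2nc(-c3ccc(OC)c(OC)c3)cc3cc(C)ccc23)c1`: 7860 nM
Compound 3, `COc1ccc(-c2cc3cc(C)ccc3c(-c3cccc(N)c3)n2)cc1OC`: 450 nM

Of these three compounds, compound 3 gives the lowest number in a functional assay on T47D cells (Homo sapiens) for cytotoxicity, read by CCK-8 assay and cell counting, with a stated time of 72 h (on this read-out higher numbers stand for weaker inhibition and lower numbers for stronger inhibition), and both of its separations from the others lie beyond the scatter, so it is the strongest inhibitor of the set: a 17-fold lower number from compound 2 to compound 3 (1.24 log units; beyond the scatter), and the step between compound 1 and compound 2 is small, a 1.8-fold higher number from compound 1 to compound 2 (0.26 log units; within the scatter).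

Compound 4, `COc1ccc(-c2cc3cc(C)ccc3c(-c3ccc(O)cc3)n2)cc1OC`, differs from compound 3 in one place: 4-hydroxyphenyl in place of 3-aminophenyl on an aromatic carbon. Two things change at once. The amino gives way to hydroxy, and the hydroxy sits at a different position on that ring than the amino did. Only the first part is covered by a measured step: compound 1 carries hydroxy where compound 3 carries amino, and a 9.6-fold lower number from compound 1 to compound 3 (0.98 log units; beyond the scatter). Read in reverse, that step points to a higher number for compound 4. For the measured compounds named here, nothing among the measured compounds shows what the shift of position on that ring does, so the size of the step is uncertain. Compound 4 is therefore expected to land near compound 1, with an 8.9-fold higher number from compound 3 to compound 4 (0.95 log units; beyond the scatter), and its estimate in this assay is 4000 nM, in a range from 1500 nM to 12000 nM.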

Compound 4, half-maximal inhibitory concentration: 4420 nM
The estimate for compound 4 lay 1.1-fold (0.04 log units) below the measured number; measured number inside the range.
By their numbers in this assay, from the lowest: compound 3; then compounds 1, 4 and 2 (each within the scatter of the next).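

In this assay, for the compounds shown here, a 1.0-fold higher number from compound 1 to compound 4 (0.01 log units; within the scatter), so on this ring the 4-hydroxyphenyl of compound 4 and the 3-hydroxyphenyl of compound 1 cannot be told apart, and the shift of the hydroxy, which no earlier pair covered, shows no effect beyond the scatter. Going by these compounds alone, the same holds for the comparison with the methyl ether, a 1.8-fold lower number from compound 2 to compound 4 (0.25 log units; within the scatter), whereas a 9.8-fold higher number from compound 3 to compound 4 (0.99 log units; beyond the scatter), which leaves the 3-aminophenyl of compound 3 as the only one of the four groups at this place that stands apart from the rest. No measurement at hand bears on why the amino compound separates from the others.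

The compounds shown leave open whether an amino group placed where compound 4 carries its hydroxy would give a number like that of compound 3, since the amino appears at only one position on this ring. They also leave open how other nitrogen groups at this place, such as a dimethylamino group or an acetamide, would compare with the plain amino group of compound 3.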